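Series notes: aryl swap on the ring nitrogen

The source may hold more compounds than are shown below. What is called first, only, known or untested is meant among the compounds shown, and "the series" means these compounds.

Compound 1, `CC(C)n1ncc2c(C(=O)Nc3cccnc3)cccc21`: in a functional assay on HepG2 cells (Homo sapiens) for inhibition, read by MTT assay, with a stated time of 72 h (on this read-out higher numbers stand for weaker inhibition and lower numbers for stronger inhibition), compound 1 gives > 40000 nM, a limit of this assay.
Compound 2, `CC(C)n1ncc2c(C(=O)NC3CCCC3)cccc21`: in this assay compound 2 gives > 40000 nM, again a limit.
Compound 3, `CC(C)n1ncc2c(C(=O)NCc3cn(-c4cccc(Br)c4)nn3)cccc21`: in this assay compound 3 gives > 40000 nM, also a limit.

Going by the values given here, the only single-point step among the measured compounds is a step that the two limits leave unreadable from compound 1 to compound 2, and with both ends at the limit its size cannot be read. Among the compounds with values here, compound 3 stands where every value so far stands, at the limit described by the limit of > 40000 nM in this assay, at which 3 of the 3 values shown sit; nothing in the measured set separates it from compound 1 or compound 2.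

Compound 4, `CC(C)n1ncc2c(C(=O)NCc3cn(-c4ccc(C(F)(F)F)cc4)nn3)cccc21`, carries 4-(trifluoromethyl)phenyl in place of 3-bromophenyl on an aromatic nitrogen. Within the data shown here, no measured step touches this part of the structure, and the one step that exists is unreadable, so there is no basis for expecting a step in this assay beyond the scatter in either direction. The step from compound 3 to compound 4 is therefore expected to be a step that the limit leaves unreadable from compound 3 to compound 4. Compound 4 is estimated at 50000 nM, within 20000 nM to 200000 nM, most probably again reported as a limit.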

Compound 4, half-maximal inhibitory concentration: > 40000 nM
Compound 4: only a limit was reported (the forecaster's own chance of this, stated with the estimate: 85%); the middle value does not contradict the limit.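

Compound 3 and compound 4 both sit at a limit in this assay, so no step can be read between them: the limit of > 40000 nM in this assay, at which 4 of the 4 values shown sit.

On these data alone, whether any group on the aromatic nitrogen or the amide-type nitrogen of the shared core gives a value short of the limit in this assay stays open.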